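A Cyano Group in Place of Bromine on Compound 4

This account rests on a few compounds, and the source may have more. Where it says the series, first, only, none or still open, it means among the compounds named here.

The measured compounds, each tested in a functional assay on SW480 cells (Homo sapiens) for cytotoxicity, read by MTT assay, with a stated time of 48 h; on this read-out higher numbers stand for weaker inhibition and lower numbers for stronger inhibition:
Compound 1 `O=c1ccoc2cc(OCc3cn(Cc4cccc(Br)c4)nn3)ccc12` gives > 100000 nM, a limit of the assay.
Compound 2 `O=c1ccoc2cc(OCc3cn(Cc4ccc(Cl)cc4Cl)nn3)ccc12` gives > 100000 nM, also a limit of the assay.
Compound 3 `O=c1ccoc2cc(OCc3cn(Cc4ccc(Br)cc4)nn3)ccc12` gives 37500 nM.

Among the compounds with values here, compound 3 is the only one with a number; the other two sit at a limit (the limit of > 100000 nM in this assay, at which 2 of the 3 values shown sit). Among the readable steps, an at least 2.6-fold lower number from compound 1 to compound 3 (0.42 log units; beyond the scatter) and an at least 2.6-fold lower number from compound 2 to compound 3 (0.42 log units; beyond the scatter) both favour the 4-bromophenyl arrangement, while a step that the two limits leave unreadable from compound 1 to compound 2 cannot be read.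

Compound 4 `N#Cc1ccc(Cn2cc(COc3ccc4c(=O)ccoc4c3)nn2)cc1` keeps that arrangement and changes only the group on the ring: cyano in place of bromo on an aromatic carbon. Within the data shown here, none of the measured steps exchange bromo for another group on the aromatic carbon, so no step bears directly on this change. Compound 4 is therefore expected to stay near compound 3, with a 1.3-fold higher number from compound 3 to compound 4 (0.12 log units; within the scatter) in this assay lying within the scatter. For compound 4 the estimate in this assay is 50000 nM, with a range from 15000 nM to 150000 nM.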

Compound 4, half-maximal inhibitory concentration: > 100000 nM
Compound 4: no number, only a limit; the forecaster's own chance of this, stated with the estimate: 30%; middle value at least 2.0-fold (0.30 log units) away from the limit.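

In this assay, the exchange of bromo for cyano at this place gives an at least 2.6-fold higher number from compound 3 to compound 4 (0.42 log units; beyond the scatter), the only step shown that replaces the group on this aromatic carbon. It shows that the 4-bromobenzyl arrangement cannot be reduced to a group in that place: with the place kept, the 4-cyanobenzyl compound 4 no longer gives a number, and compound 3 alone does. The steps from compound 1 and from compound 2 to compound 4 join limit to limit and cannot be read: the limit of > 100000 nM in this assay, at which 3 of the 4 values shown sit.

From the compounds shown here alone, how far compound 4 lies past its limit remains open, so the true size of the step is unknown. Also open, going by these compounds, is whether a methyl, a methoxy or an amine in this place would give a number in this assay.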